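This account rests on a few compounds, and the source may have more. Where it says the series, first, only, none or still open, it means among the compounds named here.

The measured compounds:
compound 1 `Nc1ccn([C@@H]2O[C@@H](CO)C=C2F)c(=O)n1`, > 100000 nM
compound 2 `Nc1nc(=O)n([C@@H]2O[C@@H](CO)C=C2F)cc1F`, > 100000 nM
compound 3 `Nc1nc(F)nc2c1ncn2[C@H]1O[C@@H](CO)C=C1F`, 19500 nM

In a functional assay on CCRF-CEM cells (Homo sapiens) for inhibition (on this read-out higher numbers stand for weaker inhibition and lower numbers for stronger inhibition), compound 1 gives > 100000 nM, which is a limit of the assay and not a number. In this assay compound 2 gives > 100000 nM, again a limit. Going by the values given here, compound 3 gives 19500 nM, the only number among the three, the other two values sitting at the limit of > 100000 nM in this assay, at which 2 of the 3 values shown sit. The difference between the core of compound 2 and the core of compound 3 is not broken down here.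

From compound 2 to compound 1 the change is hydrogen in place of fluoro on an aromatic carbon, and the step that the two limits leave unreadable from compound 2 to compound 1 cannot be read. From compound 3 to compound 4 `Nc1ncnc2c1ncn2[C@H]1O[C@@H](CO)C=C1F` the change is hydrogen in place of fluoro on an aromatic carbon, the same kind of change, though here the carbon lies between two ring nitrogen atoms, meta to a fused ring, meta to an amino group and para to a fused ring, whereas in compound 2 it sits ortho to an amino group, two atoms from the ring nitrogen, meta to a group of 8 heavy atoms and para to a group of 1 heavy atom. Set beside a step that the two limits leave unreadable from compound 2 to compound 1, the step that follows is expected to be a 1.5-fold higher number from compound 3 to compound 4 (0.19 log units; within the scatter), resting only on compound 3 with 19500 nM since the earlier pair gives no size. Compound 4 is expected to give about 30000 nM, between 8000 nM and 150000 nM.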

Compound 4, half-maximal inhibitory concentration: > 100000 nM
Compound 4: a limit, no number; the forecaster's own chance of this, stated with the estimate: 35%; middle value at least 3.3-fold (0.52 log units) away from the limit.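

In this assay, going by these compounds alone, putting hydrogen in place of fluoro on an aromatic carbon gives an at least 5.1-fold higher number from compound 3 to compound 4 (0.70 log units; beyond the scatter), so on this core the fluoro goes with the only measured number. Compound 4 gives > 100000 nM, which is a limit of the assay and not a number, so the step has a lower bound only. The same kind of change from compound 2 to compound 1 cannot be read, and nothing shows that the step carries from one core to the other because the values stop at a limit: the limit of > 100000 nM in this assay, at which 3 of the 4 values shown sit.

As far as these compounds go, it remains open whether chloro or methoxy on the carbon between two ring nitrogen atoms would give a measurable number, as fluoro does in compound 3. Also open, from the compounds shown here alone, is how the change behaves on any other core.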